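A Second Bromo on a Compound at the Limit

A few compounds are considered here, and "the series" means these few. Any claim that something is new, unique, unknown or untested is made for them only; others in the source may bear on it.

Compound 3 `O=S(=O)(/C=C/c1ccc(Br)cc1)Cc1ccc(Nc2ncnc3ccccc23)cc1` stands at the weak end of what a functional assay on NCI-H520 cells (Homo sapiens) (a higher number here means a weaker inhibitor of growth, a lower number a stronger inhibitor of growth), can report. In this assay compound 3 gives > 100000 nM, which is a limit and not a number. Compound 1 `O=S(=O)(/C=C/c1ccccc1)Cc1ccc(Nc2ncnc3ccccc23)cc1` gives > 100000 nM, also a limit. Compound 2 `O=S(=O)(/C=C/c1ccc(Cl)c(Cl)c1)Cc1ccc(Nc2ncnc3ccccc23)cc1` gives a true number, 32000 nM. Within the data shown here, the series so far therefore rests heavily on (the limit of > 100000 nM in this assay, at which 2 of the 3 values shown sit).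

Compound 4 `O=S(=O)(/C=C/c1ccc(Br)cc1)Cc1ccc(Nc2ncnc3ccc(Br)cc23)cc1` keeps all of compound 3 and changes one place: bromo in place of hydrogen on an aromatic carbon. The new bromo replaces a hydrogen on an aromatic carbon of a six-membered ring that is part of a fused system of two rings.

The closest measured change is also bromo in place of hydrogen on an aromatic carbon, but it gives no size: a step that the two limits leave unreadable from compound 1 to compound 3. The readable steps, an at least 3.1-fold lower number from compound 1 to compound 2 (0.49 log units; beyond the scatter) and an at least 3.1-fold higher number from compound 2 to compound 3 (0.49 log units; beyond the scatter), concern the 3,4-dichlorophenyl group of compound 2, elsewhere in the molecule. They show that one change can reach a true number, although compound 3 also carries a halogen and remains at its limit.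

A modest fall in the number is therefore expected, and another limit would be no surprise. The expected change is an at least 2.2-fold lower number from compound 3 to compound 4 (0.34 log units; beyond the scatter). For compound 4 the estimate is 45000 nM, with an expected range of 15000 nM to 100000 nM.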

Compound 4, concentration for 50% growth inhibition: 20000 nM
Compound 4: middle estimate off by 2.3-fold (0.35 log units), on the high side, within the range that was stated.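

In this assay the result is an at least 5.0-fold lower number from compound 3 to compound 4 (0.69 log units; beyond the scatter), so a single bromo on the fused system of two rings is enough to turn a limit into a true number. Until now only the 3,4-dichlorophenyl group of compound 2, elsewhere in the molecule, had reached a true number, and the same change of hydrogen to bromo on the outer phenyl ring gave a step that cannot be read. Compound 4 therefore shows that this carbon of the shared core, meta to a fused ring and para to a fused ring, is a place where a change can be read in growth inhibition, although the step gives only a minimum and not a full size.

On these data alone, whether this response is specific to bromo stays open: a fluoro, a methoxy or an amine on the same carbon could move the number further, less or not at all, and the same bromo added to compound 2 could behave differently again. The true size of the step also remains unknown, and much of the series still rests on one boundary: the limit of > 100000 nM in this assay, at which 2 of the 4 values shown sit.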